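The source may report more compounds than this note shows. Statements on the series, on what has been measured and on what is new or still open speak of the compounds shown alone.

Compound 1 `Cc1ccncc1-c1cccc2c1cnn2-c1cccnn1` offers no number to start from: in an ADME assay on liver (Macaca fascicularis) for metabolic stability, using microsomes, with a stated time of 10 min, tested at 0.5 uM (on this read-out higher numbers stand for a more stable compound and lower numbers for a less stable compound), compound 1 is recorded as "not determined" (no result reported) and so gives no fixed point. Compound 4 `Cc1ccncc1-c1cccc2c1cnn2-c1ccccn1` shares the core of compound 1 and differs in one group, with pyridin-2-yl in place of pyridazin-3-yl on an aromatic nitrogen of that core. Both groups are six-membered aromatic rings, but the entering ring has 1 hetero atom and the leaving ring has 2 hetero atoms.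

Within the data shown here, the only guidance comes from a pair built on a different core, which also carries its ring on an aromatic nitrogen. In this assay compound 2 `Cc1ccncc1-c1cccc2c1ncn2-c1cnccn1` gives 83% as its result. Compound 3 `Cc1ccncc1-c1cccc2c1ncn2-c1cscn1` gives 50% in the same test. The swap of pyrazin-2-yl for 1,3-thiazol-4-yl makes a large step of a number 33 percentage points lower from compound 2 to compound 3 (beyond the scatter) beyond the usual scatter, so a change of ring at such a nitrogen can matter. This single pair cannot be carried over directly, and without a number for compound 1 no step size or direction can be stated. The estimate therefore leans on the span of compound 2 and compound 3 alone, and stays wide. Compound 4 is expected to show 65% with an estimated range from 40% to 85% in this measurement.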

Compound 4, percent of the compound remaining: 19%
The estimate for compound 4 lay 46 percentage points above the measured number; the whole stated range lies above it.
By their numbers in this assay, from the lowest: compound 4; then compound 3; then compound 2.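

In this assay, among these compounds, compound 4 gives 19% but compound 1 has no number to set against it, so no step between compound 1 and compound 4 can be read. No supporting evidence bears on the result for compound 4. Still open, as far as these compounds go, is how pyridin-2-yl compares with pyridazin-3-yl at this place on the shared core.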